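Methoxy removal on the anilide core: cytotoxicity outlook

The source may report more compounds than this note shows. Statements on the series, on what has been measured and on what is new or still open speak of the compounds shown alone.

The measured pair is compound 1 `COc1ccc(C(=O)Nc2ccccc2)cc1NC(=O)C(C)F` and compound 2 `COc1ccc(NC(=O)C(C)F)cc1C(=O)Nc1ccccc1`. In an ADME assay on MDCK cells (Canis lupus familiaris) for cytotoxicity, read by cytopathic effect, with a stated time of 48 h (a lower number here means that less compound is tolerated, a higher number that more compound is tolerated), compound 2 gives 272 uM. Compound 1 reaches only a limit of the assay, > 632 uM, namely (the limit of > 632 uM in this assay, at which 1 of the 2 values shown sits). Compound 2 therefore holds the single finite number shown. Compound 3 `CC(F)C(=O)Nc1cccc(C(=O)Nc2ccccc2)c1` is not yet measured; relative to compound 2 the change is hydrogen in place of methoxy on an aromatic carbon. For the measured compounds named here, no measured step covers this change, so the expected step from compound 2 to compound 3 is a 1.3-fold higher number from compound 2 to compound 3 (0.11 log units; within the scatter), within the scatter, if anything toward more tolerated. Compound 3 is estimated at 350 uM with a range of 150 uM to 700 uM.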

Compound 3, half-maximal toxic concentration: 579 uM
Compound 3: middle estimate off by 1.7-fold (0.22 log units), on the low side, within the range that was stated.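

For the compounds shown here, replacing the methoxy para to the ((1-fluoroethyl)carbonyl)amino group with hydrogen gives the first readable step, and it is modest: a 2.1-fold higher number from compound 2 to compound 3 (0.33 log units; beyond the scatter) in this assay. The same replacement read from the core of compound 1 gives only a floor, an at least 1.0-fold lower number from compound 1 to compound 3 (0.03 log units; that floor lies within the scatter), so it cannot be sized against the first step. Compound 1 stands at a limit of the assay, not a number: the limit of > 632 uM in this assay, at which 1 of the 3 values shown sits.

Still open, on these data alone, is whether a hydroxyl or an amine at this carbon would read like hydrogen or like methoxy. Also open, as far as these compounds go, is whether a longer alkoxy chain there would move the number further.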